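Series notes: furan-2-yl for thiophen-3-yl, compound 3 to compound 4

The source may report more compounds than this note shows. Statements on the series, on what has been measured and on what is new or still open speak of the compounds shown alone.

Measured so far:
compound 1 `Oc1cccc(-c2cc(-c3ccco3)nc(-c3ccccc3Cl)c2)c1` — 1630 nM
compound 2 `Oc1cccc(-c2cc(-c3ccc(Cl)cc3)nc(-c3ccsc3)c2)c1` — 11600 nM
compound 3 `Oc1cccc(-c2cc(-c3ccsc3)nc(-c3cccc(Cl)c3)c2)c1` — 3330 nM

In a functional assay on DU-145 cells (Homo sapiens) for cytotoxicity, read by CCK-8 assay and cell counting, with a stated time of 2 days (a higher number here means a weaker inhibitor, a lower number a stronger inhibitor), compound 3 gives 3330 nM, the second highest of the three numbers; compound 1 sits below it and compound 2 above it. Among the compounds with values here, the only single-point step recorded is a 3.5-fold lower number from compound 2 to compound 3 (0.54 log units; beyond the scatter), which concerns the chlorophenyl group, not the heteroaryl.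

Compound 4 `Oc1cccc(-c2cc(-c3cccc(Cl)c3)nc(-c3ccco3)c2)c1` differs from compound 3 as follows: furan-2-yl in place of thiophen-3-yl on an aromatic carbon. Within the data shown here, no measured step bears directly on this change. Compound 1 carries the same furan-2-yl group but also a different chlorophenyl, so its value against compound 3 cannot be read as a single step. Without a direct precedent, the expected step of a 1.3-fold lower number from compound 3 to compound 4 (0.12 log units; within the scatter) is small and could fall within the scatter. Compound 4 is therefore estimated at 2500 nM, within 900 nM to 7000 nM.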

Compound 4, half-maximal inhibitory concentration: 2020 nM
Estimate against measurement, compound 4: 1.2-fold (0.09 log units) above; low and high end bracket the measured number.
By their numbers in this assay, from the lowest: compounds 1, 4 and 3 (each within the scatter of the next, the first and the last beyond it); then compound 2.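

Furan-2-yl in place of thiophen-3-yl on this carbon gives a 1.6-fold lower number from compound 3 to compound 4 (0.22 log units; within the scatter) in this assay and so does not separate the two five-membered rings here. With furan-2-yl held in place, 3-chlorophenyl in place of 2-chlorophenyl gives a 1.2-fold higher number from compound 1 to compound 4 (0.09 log units; within the scatter) and does not separate those two chlorophenyl groups either. Nothing at hand accounts for either step.

As far as these compounds go, whether an amine or a carboxylic acid on this carbon would hold the number in this range remains open. So does whether furan-2-yl and thiophen-3-yl stay interchangeable alongside 4-chlorophenyl.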